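The compounds below may be only part of what the source reports. "The series", "measured", "known", "first", "only" and "open" are said of these compounds alone.

Working notes on the series.

Within the data shown here, compound 1 `Cc1n[nH]c(C(=O)O)c1Cc1cccc(-c2cccc(F)c2)c1` gives 500 nM in an assay on isolated protein for inhibition of 2-Hydroxyacid oxidase 2 (Rattus norvegicus) (on this read-out higher numbers stand for weaker inhibition and lower numbers for stronger inhibition), and stands lowest of the three numbers measured so far. Compound 3 `Cc1n[nH]c(C(=O)O)c1Cc1ccccc1C(F)(F)F`, which also carries a trifluoromethyl, gives 1300 nM in this assay, and compound 2 `Cc1n[nH]c(C(N)=O)c1Cc1cccc(-c2ccc(F)cc2)c1`, the carboxamide, gives 1400 nM; both of these numbers lie beyond the scatter above that of compound 1.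

The next compound, compound 4 `Cc1n[nH]c(C(=O)O)c1Cc1cccc(C(F)(F)F)c1`, differs from compound 1 in one place: trifluoromethyl in place of 3-fluorophenyl on an aromatic carbon. Among the measured compounds shown here, the change removes the six-membered aromatic ring of carbon only that compound 1 carries and puts a group of four heavy atoms in its place, on an aromatic carbon of the ring meta to a large group.

For the measured compounds named here, no measured pair reproduces this change, so the expected step rests on the values alone. Because compound 3 gives 1300 nM with a trifluoromethyl in place of a second ring, compound 4 is expected to move upward, toward weaker inhibition, by about a 3.0-fold higher number from compound 1 to compound 4 (0.48 log units; beyond the scatter). On that basis compound 4 is estimated at 1500 nM in this assay, with a range from 500 nM to 4500 nM.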

Compound 4, half-maximal inhibitory concentration: 300 nM
Compound 4: middle estimate off by 5.0-fold (0.70 log units), on the high side; measured number outside the range, below it.
By their numbers in this assay, from the lowest: compounds 4 and 1 (each within the scatter of the next); then compounds 3 and 2 (each within the scatter of the next).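

On this aromatic carbon, meta to a large group, the series tolerates a large change in substituent: trifluoromethyl in place of 3-fluorophenyl gives a 1.7-fold lower number from compound 1 to compound 4 (0.22 log units; within the scatter) in this assay and stays within the scatter. The six-membered aromatic ring of carbon only in compound 1 is therefore not needed for a value at this level, and a group of 4 heavy atoms without a ring serves as well as one of 7 heavy atoms with a ring. Nothing available explains why the two groups read alike here.

The compounds shown leave open how far this tolerance extends, since only these two groups sit at this position. A nitrile, a methoxy group or an amine on the same carbon would show whether the read-out holds for groups that carry hydrogen-bond acceptors or donors.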